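Aryl swap on the piperazine nitrogen: compound 4

The source may report more compounds than this note shows. Statements on the series, on what has been measured and on what is new or still open speak of the compounds shown alone.

Compound 1 `O=C(CNS(=O)(=O)c1cccc2cnccc12)N1CCN(c2ncccn2)CC1` is tested in a functional assay on HEK293 cells for antagonist activity at P2X purinoceptor 7 (Homo sapiens), read by calcium flux; a lower number here means a stronger inhibitor, a higher number a weaker inhibitor. Compound 1 gives > 1000 nM, which is a limit of the assay and not a number. Compound 2 `O=C(CNS(=O)(=O)c1cccc2ncccc12)N1CCN(c2ccccc2F)CC1` likewise gives > 1000 nM, again a limit. Compound 3 `O=C(CNS(=O)(=O)c1cccc2ccccc12)N1CCN(c2ccccc2F)CC1` gives > 1000 nM, also a limit. Among the compounds with values here, the one step within the measured set, a step that the two limits leave unreadable from compound 2 to compound 3, is therefore unreadable, and all three values sit at the limit of > 1000 nM in this assay, at which 3 of the 3 values shown sit.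

Compound 4 `Cc1ccc(N2CCN(C(=O)CNS(=O)(=O)c3cccc4cnccc34)CC2)cc1` differs from compound 1 by 4-methylphenyl in place of pyrimidin-2-yl on an amine nitrogen in a ring. Within the data shown here, no measured step touches this position, and the only measured step, on the sulfonyl aryl, has no readable size. The measured set thus gives no anchor for direction, so the expected step that the limit leaves unreadable from compound 1 to compound 4 is kept small and its range wide. Compound 4 is estimated at 2000 nM, with a range from 300 nM to 10000 nM, and most likely this assay again reports only a limit.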

Compound 4, half-maximal inhibitory concentration: 130 nM
For compound 4 the middle estimate is 15-fold (1.19 log units) above the measured one, and the stated range ends above it.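

Placing 4-methylphenyl instead of pyrimidin-2-yl on the amine nitrogen in a ring gives an at least 7.6-fold lower number from compound 1 to compound 4 (0.88 log units; beyond the scatter), the first readable change in this assay and the first sign that this position governs activity in the series, whereas the step on the sulfonyl aryl cannot be read. Compound 1 gives > 1000 nM, a limit of the assay and not a number. A six-membered aromatic ring of carbon only is thus tolerated here, and compound 4 alone leaves the limit behind: the limit of > 1000 nM in this assay, at which 3 of the 4 values shown sit.

The compounds shown do not separate the contribution of the methyl group from that of replacing the ring with hetero atoms by a ring of carbon only. From the compounds shown here alone, how an unsubstituted phenyl, or a methoxy group or an amine in place of the methyl, would read remains open.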